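This account rests on a few compounds, and the source may have more. Where it says the series, first, only, none or still open, it means among the compounds named here.

Compound 1 `Cc1c(C(=O)NCc2cccc(C(F)(F)F)c2)cnn1-c1ccccc1`, compound 2 `Cc1c(C(=O)NCc2cccc(C(F)(F)F)c2)cnn1-c1ccc(F)cc1`, compound 3 `Cc1cccc(-n2ncc(C(=O)NCc3cccc(C(F)(F)F)c3)c2C)c1`.

In a functional assay on cells for antagonist activity at C-C chemokine receptor type 1 (Homo sapiens), read by FLIPR and calcium flux (on this read-out lower numbers stand for stronger inhibition and higher numbers for weaker inhibition), compound 1 gives only the limit of the assay, > 3000 nM. Compound 2 gives 790 nM in this assay. For compound 3 this assay again records only a limit, > 3000 nM. Compound 3 therefore stands at the weak end of the numbers shown, where two of the three values sit (the limit of > 3000 nM in this assay, at which 2 of the 3 values shown sit). Its step from compound 2 is an at least 3.7-fold higher number from compound 2 to compound 3 (0.57 log units; beyond the scatter), while a step that the two limits leave unreadable from compound 1 to compound 3.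

Compound 4 `Cc1c(C(=O)NCc2cccc(C(F)(F)F)c2)cnn1-c1cccc(C(F)(F)F)c1` differs from compound 3 by trifluoromethyl in place of methyl on an aromatic carbon. Among the compounds with values here, no measured step changes a methyl into a trifluoromethyl. The nearest step on the same ring, an at least 3.7-fold lower number from compound 1 to compound 2 (0.57 log units; beyond the scatter), came from a fluoro in place of hydrogen, and the step of an at least 3.7-fold higher number from compound 2 to compound 3 (0.57 log units; beyond the scatter) shows how sharply a change on that ring can move the number. Since compound 3 rests at the limit, compound 4 is expected to stay weak, with a step of an at least 1.2-fold lower number from compound 3 to compound 4 (0.07 log units; that floor lies within the scatter) in this assay. The estimate for compound 4 is 2500 nM, between 600 nM and 10000 nM.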

Compound 4, half-maximal inhibitory concentration: > 3000 nM
Compound 4 ended at the assay's limit (the forecaster's own chance of this, stated with the estimate: 55%); middle value at least 1.2-fold (0.07 log units) away from the limit.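

Replacing the 4-fluorophenyl on the aromatic nitrogen with 3-(trifluoromethyl)phenyl gives an at least 3.7-fold higher number from compound 2 to compound 4 (0.57 log units; beyond the scatter), so compound 4 joins compound 3 as a second compound with a group at this ring position that does not keep the number of compound 2. In this assay compound 4 gives only a limit of the assay, and the steps from compound 1 and compound 3 to compound 4 cannot be read, which leaves methyl and trifluoromethyl unseparated here. Compound 2 remains the only compound with a number rather than a limit, and the compounds now fall at one end: the limit of > 3000 nM in this assay, at which 3 of the 4 values shown sit.

As far as these compounds go, how far compound 1, compound 3 and compound 4 lie beyond that limit stays open. So does whether a 4-chlorophenyl or a 4-methoxyphenyl on the same nitrogen would match or improve on the 4-fluorophenyl of compound 2.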